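Aryl versus cyclohexyl amines on the shared core

The compounds below may be only part of what the source reports. "The series", "measured", "known", "first", "only" and "open" are said of these compounds alone.

Three members of the series have been run through a functional assay on ECa-109 cells for inhibition, with ECa-109 cell line (Homo sapiens) as the target, read by sulforhodamine B assay; on this read-out lower numbers stand for stronger inhibition and higher numbers for weaker inhibition. Compound 1 `O=C1C=C(Nc2ccc(I)cc2)C(=O)c2c1nc1n2[C@H]2OC[C@@H](O)[C@H]2OC1` gives 2300 nM in this assay. Compound 2 `CCc1ccc(NC2=CC(=O)c3nc4n(c3C2=O)[C@H]2OC[C@@H](O)[C@H]2OC4)cc1` gives 3080 nM in this assay; the step of a 1.3-fold higher number from compound 1 to compound 2 (0.13 log units; within the scatter) separates them. Compound 3 `O=C1C=C(NC2CCCCC2)C(=O)c2c1nc1n2[C@H]2OC[C@@H](O)[C@H]2OC1` returns only a limit of the assay, > 16000 nM. Compound 3 thus stands at the weak end of the three values shown, as the limit of > 16000 nM in this assay, at which 1 of the 3 values shown sits, records. The steps of an at least 6.9-fold higher number from compound 1 to compound 3 (0.84 log units; beyond the scatter) and an at least 5.1-fold higher number from compound 2 to compound 3 (0.71 log units; beyond the scatter) both run from an aryl amine to a cyclohexyl amine, and both weaken inhibition.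

Compound 4 `COc1ccccc1NC1=CC(=O)c2nc3n(c2C1=O)[C@H]1OC[C@@H](O)[C@H]1OC3` is not yet measured. It differs from compound 3 by 2-methoxyphenyl in place of cyclohexyl on an amine nitrogen. A six-membered aromatic ring of carbon only, here as 2-methoxyphenyl, returns to the amine nitrogen, the reverse of the two weakening steps. Those steps are the ones that bear on this change, so for compound 4 a step down in number, beyond the scatter, is expected, roughly an at least 5.0-fold lower number from compound 3 to compound 4 (0.69 log units; beyond the scatter). The estimate for compound 4 in this assay is 3200 nM, with a range from 1200 nM to 9000 nM.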

Compound 4, half-maximal inhibitory concentration: > 4000 nM
Compound 4 ended at the assay's limit; the forecaster's own chance of this, stated with the estimate: 10%; at least 1.2-fold (0.09 log units) between middle value and limit.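

Compound 4 gives no number in this assay, only a limit: the limit of > 4000 nM in this assay, at which 1 of the 4 values shown sits.

An aromatic ring on the amine nitrogen therefore does not by itself ensure a measured value in the range of the 4-iodophenyl and 4-ethylphenyl compounds. The readable steps are an at least 1.2-fold higher number from compound 2 to compound 4 (0.11 log units; that floor lies within the scatter) and an at least 1.7-fold higher number from compound 1 to compound 4 (0.24 log units; that floor lies within the scatter), and since both floors lie within the scatter, 2-methoxyphenyl cannot yet be set apart from either group. The step between compound 3 and compound 4 cannot be read, so any gain from replacing cyclohexyl with 2-methoxyphenyl remains unshown.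

Still open, from the compounds shown here alone, is how far compound 4 lies past its limit, and whether the methoxy group or its place on the ring governs this result. A 4-methoxyphenyl or a benzyl group on the amine nitrogen would bear on both questions.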